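A few compounds are considered here, and "the series" means these few. Any claim that something is new, unique, unknown or untested is made for them only; others in the source may bear on it.

Compound 1 `Cc1ccc(NC(=O)Nc2ccncc2)cc1` and compound 2 `Cc1ccc(NC(=O)Nc2ccncc2)c(C)c1` share one core. In a functional assay on the whole organism with Mus musculus as the target, in the maximal electroshock model, with a stated time of 30 min (a higher number here means that more compound is needed for the effect, a lower number that less compound is needed), compound 1 gives > 300 mg/kg, a limit of the assay rather than a number. Compound 2 in this assay likewise gives > 300 mg/kg, again a limit. Among the measured compounds shown here, the one measured step, a step that the two limits leave unreadable from compound 1 to compound 2, therefore has no readable size, since both readings sit at the limit of > 300 mg/kg in this assay, at which 2 of the 2 values shown sit. For the measured compounds named here, compound 2 thus stands at the limit, as does the only other value shown.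

Compound 3 `Cc1cc(C)c(NC(=O)Nc2ccncc2)c(Cl)c1` is not yet measured. It differs from compound 2 by chloro in place of hydrogen on an aromatic carbon. Going by the values given here, the only measured step, a step that the two limits leave unreadable from compound 1 to compound 2, offers no readable size, so there is no basis to expect compound 3 to move away from the limit in either direction. For compound 3 in this assay the expected value is 400 mg/kg, within a range from 150 mg/kg to 1200 mg/kg. The expected step is a step that the limit leaves unreadable from compound 2 to compound 3, with the result most likely reported only as a limit.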

Compound 3, minimum effective dose: 100 mg/kg
Compound 3: middle estimate off by 4.0-fold (0.60 log units), on the high side; measured number below the stated range.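

Chloro in place of hydrogen, on an aromatic carbon ortho to a large group and meta to two methyl groups, brings an at least 3.0-fold lower number from compound 2 to compound 3 (0.47 log units; beyond the scatter) in this assay, so less compound is needed for the effect. Among the compounds shown here, the step from compound 1 to compound 2 could not be read, so this is the first sign that a change on this ring can move the result at all. Compound 3 is also the only compound shown with a real number, as the other two remain at a limit: the limit of > 300 mg/kg in this assay, at which 2 of the 3 values shown sit.

On these data alone, whether this step belongs to chloro itself stays open, and fluoro, bromo or methoxy at the same place would be needed to tell. Also open, as far as these compounds go, is whether chloro would bring a similar step without the two methyl groups.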